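The source may hold more compounds than are shown below. What is called first, only, known or untested is meant among the compounds shown, and "the series" means these compounds.

Three measured compounds and one not yet measured are compared in a functional assay on T47D cells (Homo sapiens) for cytotoxicity, read by sulforhodamine B assay, with a stated time of 48 h; a lower number here means a stronger inhibitor of growth, a higher number a weaker inhibitor of growth. Compound 1, `ClCc1ccccc1Cn1cnc2c(Cl)nc(Cl)nc21`, gives 1990 nM in this assay. Compound 2, `ClCc1ccccc1Cn1cnc2c(Cl)ncnc21`, differs from compound 1 by a single change, (hydrogen in place of chloro on an aromatic carbon). In this assay compound 2 gives 17800 nM, and the step of an 8.9-fold higher number from compound 1 to compound 2 (0.95 log units; beyond the scatter) shows that the compound without the chloro group is the weaker inhibitor of growth.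

Compound 3, `ClCc1ccc(Cn2cnc3nc(Cl)nc(Cl)c32)cc1`, has the same atoms as compound 1 joined differently; the difference between the two cores is not broken down here. In this assay compound 3 gives 10200 nM, a number beyond the scatter from compound 1 but within the scatter of compound 2, so compound 2 and compound 3 cannot be put in order.

Compound 4, `ClCc1ccc(Cn2cnc3ncnc(Cl)c32)cc1`, has not yet been measured. It differs from compound 3 by hydrogen in place of chloro on an aromatic carbon. This is the same change as the one from compound 1 to compound 2, the surroundings of the place being described in identical words, and it occurs twice among these compounds. Because an 8.9-fold higher number from compound 1 to compound 2 (0.95 log units; beyond the scatter) was a clear weakening, the same weakening is expected from compound 3 to compound 4, so compound 4 is expected to show a step of a 7.8-fold higher number from compound 3 to compound 4 (0.89 log units; beyond the scatter). Among the compounds with values here, compound 4 is thus estimated at about 80000 nM in this assay, most likely between 25000 nM and 250000 nM, with the uncertainty that only one earlier example of the change exists and that it sits on a differently joined core.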

Compound 4, concentration for 50% growth inhibition: 1280 nM
Beside the measured number, compound 4's estimate is 63-fold (1.80 log units) above it; measured number outside the range, below it.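

In this assay the swap of chloro for hydrogen gives an 8.0-fold lower number from compound 3 to compound 4 (0.90 log units; beyond the scatter) and so makes the compound without the chloro group the stronger inhibitor of growth, the reverse of what the same change did on the core of compound 1. The two steps are similar in size but run in opposite directions, and the gap between them is clear: the same change on two cores in this assay, an 8.9-fold higher number (0.95 log units; beyond the scatter) from compound 1 to compound 2 and an 8.0-fold lower number (0.90 log units; beyond the scatter) from compound 3 to compound 4, 71-fold (1.85 log units) apart, beyond the scatter of two such steps. Within the data shown here, this shows that, for these two pairs, the effect of the change cannot simply be carried from one core to the other, even though the change itself is the same; it does not show why the direction reverses, and with only two pairs, whose atoms are joined differently, neither direction can be called the rule for this series.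

The compounds shown leave open what happens when the chloro group on that aromatic carbon gives way to something other than hydrogen, such as an amine or a methoxy group, and whether the two cores would then also part ways. They also leave open how much the chloromethyl group contributes, which a plain methyl or a hydroxymethyl group in its place on each core could test.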